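A Pivalate for a Toluate on Two Related Cores

The source may hold more compounds than are shown below. What is called first, only, known or untested is meant among the compounds shown, and "the series" means these compounds.

Compound 1 `C=C1[C@H](OC(C)=O)[C@@H](OC(C)=O)[C@@H](OC(C)=O)C(C)(C)/C=C/[C@H](C)[C@H](OC(=O)c2ccccc2)[C@@]2(O)C[C@@](C)(OC(=O)C(C)(C)C)[C@H](OC(C)=O)[C@@H]2[C@H]1OCC(C)C` and compound 2 `C=C1[C@H](OC(C)=O)[C@@H](OC(C)=O)[C@@H](OC(C)=O)C(C)(C)/C=C/[C@H](C)[C@H](OC(=O)c2ccccc2)[C@@]2(O)C[C@@](C)(OC(=O)c3cccc(C)c3)[C@H](OC(C)=O)[C@@H]2[C@H]1OCC(C)C` share one core; in a functional assay on NCI/ADR-RES cells (Homo sapiens) for positive allosteric modulation, read by MTT assay, with a stated time of 48 h, tested at 10 uM (a higher number here means a weaker inhibitor, a lower number a stronger inhibitor), compound 1 gives 500 nM and compound 2 gives 1510 nM. The change between them, (tert-butyl in place of 3-methylphenyl on a carbonyl carbon), produced a 3.0-fold lower number from compound 2 to compound 1 (0.48 log units; beyond the scatter). Compound 3 `C=C1[C@H](OC(C)=O)[C@@H](OC(=O)c2cccc(C)c2)[C@@H](OC(C)=O)C(C)(C)/C=C/[C@H](C)[C@H]2O[C@]3(C)C[C@@]2(OC(=O)c2ccccc2)[C@H]([C@H]3OC(C)=O)[C@H]1OCC(C)C` rests on a different core, and the difference between the two cores is not broken down here; in this assay compound 3 gives 6570 nM, the highest of the three numbers. Compound 4 `C=C1[C@H](OC(C)=O)[C@@H](OC(=O)C(C)(C)C)[C@@H](OC(C)=O)C(C)(C)/C=C/[C@H](C)[C@H]2O[C@]3(C)C[C@@]2(OC(=O)c2ccccc2)[C@H]([C@H]3OC(C)=O)[C@H]1OCC(C)C` carries the same change as compound 1 does against compound 2, namely (tert-butyl in place of 3-methylphenyl on a carbonyl carbon), on the core of compound 3. Among the measured compounds shown here, because the single earlier example, a 3.0-fold lower number from compound 2 to compound 1 (0.48 log units; beyond the scatter), lowered the number, a step of similar direction, a 2.5-fold lower number from compound 3 to compound 4 (0.40 log units; beyond the scatter), is expected here, though only one precedent on another core supports it. Compound 4 is therefore estimated at 2600 nM, within 1000 nM to 7000 nM.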

Compound 4, half-maximal inhibitory concentration: 2750 nM
Compound 4: the middle estimate sits 1.1-fold (0.02 log units) below what was measured; the range from low to high includes it.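

In this assay the exchange of 3-methylphenyl for tert-butyl on a carbonyl carbon gave a 2.4-fold lower number from compound 3 to compound 4 (0.38 log units; beyond the scatter) on this second core. Set beside the earlier case, the step carries over from one core to the other in direction and, within the scatter, in size: the same change on two cores in this assay, a 3.0-fold lower number (0.48 log units; beyond the scatter) from compound 2 to compound 1 and a 2.4-fold lower number (0.38 log units; beyond the scatter) from compound 3 to compound 4, 1.3-fold (0.10 log units) apart, within the scatter of two such steps. Among the compounds shown here, this rests on only two pairs on two cores, so it sets no rule for the whole series and does not explain why the number falls.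

The compounds shown leave open whether a longer chain, a cyclohexyl ring or an amine on that carbonyl carbon would behave as tert-butyl does. They also leave open whether the step would hold on any further core.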